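Carbamate ester swap carried onto the second core

The source may report more compounds than this note shows. Statements on the series, on what has been measured and on what is new or still open speak of the compounds shown alone.

Compound 1 `CC(C)CCOC(=O)Nc1nc(=O)n([C@@H]2O[C@H](C)[C@H]3OC(=O)O[C@H]32)cc1F` and compound 2 `C[C@H]1O[C@@H](n2cc(F)c(NC(=O)Oc3ccc([N+](=O)[O-])cc3)nc2=O)[C@@H]2OC(=O)O[C@@H]21` share one core; compound 3 `CCC(C)COC(=O)Nc1nc(=O)n([C@@H]2O[C@H](C)[C@@H](O)[C@H]2O)cc1F` and the not yet measured compound 4 `C[C@H]1O[C@@H](n2cc(F)c(NC(=O)Oc3ccc([N+](=O)[O-])cc3)nc2=O)[C@H](O)[C@@H]1O` share a second core that differs from the first only in the sugar portion. In a functional assay on NCI-H69 cells (Homo sapiens) for cytotoxicity, read by MTT assay, with a stated time of 3 days (on this read-out higher numbers stand for weaker inhibition and lower numbers for stronger inhibition), compound 1 gives 310 ug/mL, compound 2 gives 30 ug/mL and compound 3 gives 370 ug/mL. For the measured compounds named here, compound 3 thus stands highest of the three numbers so far: its gap to compound 1 lies within the scatter, while its gap to compound 2 lies beyond it.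

The change under study is 4-nitrophenyl in place of 2-methylbutyl on an oxygen next to a carbonyl group. Going by the values given here, one measured step bears on it directly, a 10-fold lower number from compound 1 to compound 2 (1.01 log units; beyond the scatter), where the same 4-nitrophenyl entered on an oxygen next to a carbonyl group, on the first core. No measurement shows how the second core answers this change, so the direction and rough size are carried over from that step, with a wider range to cover the different core.

The number for compound 4 in this assay is therefore expected to drop, by about a 10-fold lower number from compound 3 to compound 4 (1.00 log units; beyond the scatter). Compound 4 is estimated at 37 ug/mL, with a range from 15 ug/mL to 90 ug/mL.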

Compound 4, half-maximal inhibitory concentration: 100 ug/mL
Compound 4: middle estimate off by 2.7-fold (0.43 log units), on the low side; the measured number lies above the stated range.
By their numbers in this assay, from the lowest: compound 2; then compound 4; then compounds 1 and 3 (each within the scatter of the next).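

In this assay, 4-nitrophenyl in place of 2-methylbutyl on an oxygen next to a carbonyl group gives a 3.7-fold lower number from compound 3 to compound 4 (0.57 log units; beyond the scatter) on the second core, so the direction of a 10-fold lower number from compound 1 to compound 2 (1.01 log units; beyond the scatter) now holds on both cores, although the printed step is smaller on the second. With 4-nitrophenyl held fixed, the change in the sugar portion alone gives a 3.3-fold higher number from compound 2 to compound 4 (0.52 log units; beyond the scatter) and leaves compound 2 with the lowest number of the four, so the sugar portion also moves the number in this pair. Nothing at hand bears on why the step differs in size between the two cores.

From the compounds shown here alone, two points remain open. For the compounds shown here, with only two pairs, it cannot be told whether the lower number belongs to 4-nitrophenyl specifically or would also appear with an unsubstituted phenyl or a longer chain such as octyl on the same oxygen. The sugar change also remains unread for an alkyl carbamate, since compound 1 and compound 3 differ in the chain as well as in the sugar portion, and their values therefore do not isolate it.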